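The compounds below may be only part of what the source reports. "The series", "measured", "known", "first", "only" and "open" are said of these compounds alone.

Working notes on the series. Compound 1 `CN1CCN(S(=O)(=O)c2ccc(-c3ccc4c(Nc5ccc(OCc6cccc(F)c6)c(Cl)c5)nccc4c3)cc2)CC1`, compound 2 `CN1CCCN(S(=O)(=O)c2ccc(-c3ccc4c(Nc5ccc(OCc6cccc(F)c6)c(Cl)c5)nccc4c3)cc2)CC1` and compound 3 `CN1CCCN(S(=O)(=O)c2ccc(-c3ccc4ccnc(Nc5ccc(OCc6cccc(F)c6)c(Cl)c5)c4c3)cc2)CC1` have been tested in a toxicity assay on HepG2 cells (Homo sapiens) for cytotoxicity, read by MTT assay, with a stated time of 48 h; on this read-out higher numbers stand for lower toxicity in this test and lower numbers for higher toxicity in this test; compound 4 `CN1CCN(S(=O)(=O)c2ccc(-c3ccc4ccnc(Nc5ccc(OCc6cccc(F)c6)c(Cl)c5)c4c3)cc2)CC1` has not. In this assay compound 1 gives > 15 uM, which is a limit of the assay and not a number. Compound 2 gives > 15 uM in this assay, again only a limit. Compound 3 gives > 15 uM in this assay, also a limit.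

The change from compound 2 to compound 1 is 4-methylpiperazin-1-yl in place of 4-methyl-1,4-diazepan-1-yl on a sulfonyl sulfur. The step that the two limits leave unreadable from compound 2 to compound 1 cannot be read, since both ends of it sit at a limit. The difference between the core of compound 2 and the core of compound 3 is not broken down here. Compound 4 is reached from compound 3 by 4-methylpiperazin-1-yl in place of 4-methyl-1,4-diazepan-1-yl on a sulfonyl sulfur, the same change as that from compound 2 to compound 1, made at the same place. Because (the limit of > 15 uM in this assay, at which 3 of the 3 values shown sit), the change has no measured effect to rest on in this series.

The expected step from compound 3 to compound 4 is a step that the limit leaves unreadable from compound 3 to compound 4, set to no change. This rests on the fact that the same change between compound 2 and compound 1 gave a step that the two limits leave unreadable from compound 2 to compound 1, with every tested compound at the limit. The estimate for compound 4 in this assay is 20 uM, expected to lie between 10 uM and 60 uM, and most likely to be reported again only as a limit.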

Compound 4, half-maximal toxic concentration: > 15 uM
Compound 4 gave a limit, no number (the forecaster's own chance of this, stated with the estimate: 85%); the middle value lies beyond the limit too.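

In this assay compound 4 gives > 15 uM, again a limit of the assay and not a number. Among the compounds shown here, the step between compound 3 and compound 4 therefore cannot be read, and no new step comes out of this result. The compounds shown leave open whether 4-methylpiperazin-1-yl in place of 4-methyl-1,4-diazepan-1-yl, or the difference in core, changes the read-out at all: the limit of > 15 uM in this assay, at which 4 of the 4 values shown sit.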